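Cytotoxicity notes: oxazolidinone replaced by cyanopyrrolidinone

This account rests on a few compounds, and the source may have more. Where it says the series, first, only, none or still open, it means among the compounds named here.

The series is read in a toxicity assay on HepG2 2.2.15 cells (Homo sapiens) for cytotoxicity, read by CellTiter-Glo; on this read-out lower numbers stand for higher toxicity in this test and higher numbers for lower toxicity in this test. Compound 1 `O=C1OC(c2ccccc2)CN1c1cnn2c1CN(C(=O)Nc1cc(F)c(F)c(F)c1)C(C1CC1)C2` carries a 2-oxo-5-phenyl-1,3-oxazolidin-3-yl group on an aromatic carbon of its core. In this assay compound 1 gives 7410 nM. Compound 3 `C[C@H]1Cn2ncc(N3CC(c4ccccc4)CC3=O)c2CN1C(=O)Nc1cc(F)c(F)c(F)c1`, on a related core, is the nearest neighbour; in this assay compound 3 gives 12800 nM. The gap between compound 1 and compound 3 lies within the scatter, so the two full numbers read as one level of toxicity. Compound 2 `C[C@H]1Cn2ncc(N3CC(c4ccccc4)CC3=O)c2CN1S(=O)(=O)Nc1cc(F)c(F)c(F)c1` is reported in this assay only as a limit of the assay, > 2000 nM. This is the line (the limit of > 2000 nM in this assay, at which 1 of the 3 values shown sits), and it gives no number for comparison.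

Among the measured compounds shown here, no step between measured compounds is available, so the expectation for the next change rests on the structures alone. Compound 4 `N#CC1CC(=O)N(c2cnn3c2CN(C(=O)Nc2cc(F)c(F)c(F)c2)C(C2CC2)C3)C1` differs from compound 1 by 4-cyano-2-oxopyrrolidin-1-yl in place of 2-oxo-5-phenyl-1,3-oxazolidin-3-yl on an aromatic carbon.

The step in this assay is expected to be small, either a somewhat higher number or none beyond the scatter. Compound 4 is expected at 10000 nM, with a range from 4000 nM to 25000 nM. This corresponds to an expected step of a 1.3-fold higher number from compound 1 to compound 4 (0.13 log units; within the scatter).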

Compound 4, half-maximal cytotoxic concentration: > 200000 nM
Compound 4: only a limit was reported (the forecaster's own chance of this, stated with the estimate: 30%); at least 20-fold (1.30 log units) between middle value and limit.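

The step at this position is large: with 4-cyano-2-oxopyrrolidin-1-yl in place of 2-oxo-5-phenyl-1,3-oxazolidin-3-yl on an aromatic carbon of the shared core, this assay shows an at least 26-fold higher number from compound 1 to compound 4 (1.43 log units; beyond the scatter), so the group held here can strongly change the read-out, and higher numbers here stand for lower toxicity in this test. Among the compounds shown here, the earlier compounds offered no step between measured compounds, and their full numbers only read as one level of toxicity, so this is the first direct reading on this position. Compound 4 is reported only as a limit of the assay, so the true size of the step stays unfixed, and no measured property in the data accounts for it.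

The change removes the phenyl ring and the ring oxygen and brings in the nitrile all at once, so the compounds shown do not tell which of these parts carries the step. Unsubstituted 2-oxopyrrolidin-1-yl, or an amine or a carboxylic acid in place of the nitrile on the same ring, would begin to separate these parts on the core of compound 1.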